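A few compounds are considered here, and "the series" means these few. Any claim that something is new, unique, unknown or untested is made for them only; others in the source may bear on it.

Measured so far:
- compound 1 `COc1ccc([C@@H]2CC(=O)c3c(O)cc(OCc4cn(Cc5ccccc5Cl)nn4)cc3O2)cc1O`: 6140 nM
- compound 2 `COc1ccc([C@@H]2CC(=O)c3c(O)cc(OCc4cn(Cc5ccc(Cl)cc5)nn4)cc3O2)cc1O`: 17800 nM
- compound 3 `COc1ccc([C@@H]2CC(=O)c3c(O)cc(OCc4cn(CCCO)nn4)cc3O2)cc1O`: 16700 nM

In a functional assay on RAW264.7 cells (Mus musculus) for inhibition, read by Griess assay, with stated times of 2 h and 24 h (on this read-out lower numbers stand for stronger inhibition and higher numbers for weaker inhibition), compound 1 gives 6140 nM, compound 2 gives 17800 nM and compound 3 gives 16700 nM. Compound 3 holds the second highest of the three numbers; its nearest neighbour is compound 2, with which it sits within the scatter (a 1.1-fold lower number from compound 2 to compound 3 (0.03 log units; within the scatter)), while compound 1 is furthest off (a 2.7-fold higher number from compound 1 to compound 3 (0.43 log units; beyond the scatter)). The two substituents at the saturated chain carbon bound to the aromatic nitrogen therefore fall into two groups: the 2-chlorophenyl of compound 1 gives the lowest number, and 4-chlorophenyl or 2-hydroxyethyl both give a clearly higher one (a 2.9-fold higher number from compound 1 to compound 2 (0.46 log units; beyond the scatter)).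

Compound 4 `CCCn1cc(COc2cc(O)c3c(c2)O[C@H](c2ccc(OC)c(O)c2)CC3=O)nn1` is not yet measured in this assay. It differs from compound 3 by hydrogen in place of hydroxy on a saturated chain carbon, three bonds along the chain from an aromatic nitrogen. Going by the values given here, no measured step removes a hydroxy at this position; the steps that bear on it only show that exchanging a 2-hydroxyethyl for a 4-chlorophenyl chain end leaves the number unchanged (a 1.1-fold lower number from compound 2 to compound 3 (0.03 log units; within the scatter)), so the chain end appears tolerant. The expected step from compound 3 is a 1.1-fold lower number from compound 3 to compound 4 (0.05 log units; within the scatter), within the scatter. For compound 4 the estimate in this assay is 15000 nM, with a range of 6000 nM to 40000 nM.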

Compound 4, half-maximal inhibitory concentration: 9670 nM
The estimate for compound 4 lay 1.6-fold (0.19 log units) above the measured number; measured number inside the range.
By their numbers in this assay, from the lowest: compounds 1, 4, 3 and 2 (each within the scatter of the next, the first and the last beyond it).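

Removing the hydroxy from the 3-hydroxypropyl chain end in this assay gives no step beyond the scatter (a 1.7-fold lower number from compound 3 to compound 4 (0.24 log units; within the scatter)), so on this read-out the hydroxy at this place is not required, and a plain propyl is accepted in its stead. The propyl compound also blurs the earlier division of the chain ends into two groups: it lies within the scatter of both the 2-chlorophenyl compound (a 1.6-fold higher number from compound 1 to compound 4 (0.20 log units; within the scatter)) and the 4-chlorophenyl compound (a 1.8-fold lower number from compound 2 to compound 4 (0.26 log units; within the scatter)), although those two remain beyond the scatter of each other (a 2.9-fold higher number from compound 1 to compound 2 (0.46 log units; beyond the scatter)), and so compound 1 no longer stands clearly apart from every other chain end. No measurement at hand accounts for this tolerance.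

The compounds shown leave open whether an amine or a carboxylic acid at the end of the propyl chain, or a longer chain such as pentyl, stays within this same narrow band of values. Also open, on these data alone, is whether a plain phenyl or a 3-chlorophenyl in place of the 2-chlorophenyl separates the aromatic chain ends more clearly from the propyl of compound 4.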